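The compounds below may be only part of what the source reports. "The series", "measured", "known", "first", "only" and "open" are said of these compounds alone.

Measured so far:
Compound 1 `Cc1nc(-c2ccc(C(F)(F)F)cc2)sc1CNc1ccc(C(=O)O)cc1`: in a functional assay on CHO cells for agonist activity at Free fatty acid receptor 1 (Homo sapiens), read by a luciferase reporter (a higher number here means a larger maximal response, a lower number a smaller maximal response), compound 1 gives 10%.
Compound 2 `O=C(O)CSc1ccc(NCc2cccc(Oc3ccccc3)c2)cc1`: in this assay compound 2 gives 84%.

Compound 2 thus stands highest of the two numbers in hand, and compound 1 lies well under it, a gap beyond the usual scatter. Compound 3 `CN(C)C(=O)CCc1ccc(NCc2cccc(Oc3ccccc3)c2)cc1` is not yet measured. It differs from compound 2 in one place: 2-(dimethylcarbamoyl)ethyl in place of (carboxymethyl)sulfanyl on an aromatic carbon. Within the data shown here, no measured pair shows this exact change, so the step is a guess. The expected step is a fall beyond the scatter, a number 49 percentage points lower from compound 2 to compound 3 (beyond the scatter). For compound 3 in this assay the estimated value is 35%, with a range from 5% to 75%.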

Compound 3, largest response reached (reported as percent of maximum), in percent of the reference or control that the assay uses: 50%
Compound 3: middle estimate off by 15 percentage points, on the low side; low and high end bracket the measured number.
By their numbers in this assay, from the lowest: compound 1; then compound 3; then compound 2.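

Exchanging (carboxymethyl)sulfanyl for 2-(dimethylcarbamoyl)ethyl on this aromatic carbon gives a number 34 percentage points lower from compound 2 to compound 3 (beyond the scatter) in this assay, so the response depends on what sits at this position. It is not lost, however: compound 3, whose entering group has no hydrogen-bond donor and no carboxylic acid, still gives 50%. Nothing available explains the fall.

The change replaces the sulfur, the carboxylic acid and the chain at once, so the compounds shown cannot say which of these accounts for the step. A 2-carboxyethyl group at this position would keep the acid without the sulfur.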